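Moving the thiophene attachment in a hydroxymethyl-bearing lactam

The compounds below may be only part of what the source reports. "The series", "measured", "known", "first", "only" and "open" are said of these compounds alone.

Measured compounds:
Compound 1, `COc1ccc([C@@H]2C(c3ccoc3)C(=O)N2c2cc(OC)c(OC)c(OC)c2)cc1`: 150 nM
Compound 2, `COc1ccc([C@@H]2[C@@H](C(O)c3ccsc3)C(=O)N2c2cc(OC)c(OC)c(OC)c2)cc1`: 990 nM
Compound 3, `COc1ccc([C@@H]2C(c3cccs3)C(=O)N2c2cc(OC)c(OC)c(OC)c2)cc1`: 64 nM

In a functional assay on MCF7 cells (Homo sapiens) for antiproliferative activity, read by MTT assay (on this read-out higher numbers stand for weaker inhibition and lower numbers for stronger inhibition), compound 2 gives the highest number of the three, with compound 1 closest and compound 3 furthest, both gaps beyond the scatter. Compound 4, `COc1ccc([C@@H]2[C@@H](C(O)c3cccs3)C(=O)N2c2cc(OC)c(OC)c(OC)c2)cc1`, has not been measured in this assay. It differs from compound 2 in one place: thiophen-2-yl in place of thiophen-3-yl on a saturated chain carbon bound to an oxygen on a saturated carbon and a saturated ring carbon.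

Among the measured compounds shown here, the only measured step that bears on this change is a 2.3-fold lower number from compound 1 to compound 3 (0.37 log units; beyond the scatter). That step moves the attachment of a five-membered heteroaryl to its 2-position on a ring carbon, whereas the change to compound 4 does the same on the chain carbon carrying the hydroxyl; the heteroatom also differs there. Taken as a rough guide, a modest lowering of the number is expected, estimated at a 1.8-fold lower number from compound 2 to compound 4 (0.26 log units; within the scatter). Compound 4 is therefore expected to give about 550 nM in this assay, within a range of 250 nM to 1300 nM.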

Compound 4, half-maximal inhibitory concentration: 1200 nM
For compound 4 the middle estimate is 2.2-fold (0.34 log units) below the measured one, within the range that was stated.
By their numbers in this assay, from the lowest: compound 3; then compound 1; then compounds 2 and 4 (each within the scatter of the next).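

In this assay the change gives a 1.2-fold higher number from compound 2 to compound 4 (0.08 log units; within the scatter), so on the saturated chain carbon bound to an oxygen, thiophen-2-yl and thiophen-3-yl cannot be told apart in this read-out. The earlier step, a 2.3-fold lower number from compound 1 to compound 3 (0.37 log units; beyond the scatter), lay beyond the scatter, but it changed the heteroatom as well as the attachment and sat on a ring carbon, and no such separation appears at this position. Nothing available accounts for this lack of separation.

The compounds shown leave open whether this chain carbon would tell other groups apart, such as phenyl in place of the thiophene. They also leave open how an amine or a methoxy group in place of the hydroxyl would read in this assay on either thiophene.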